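The source may report more compounds than this note shows. Statements on the series, on what has been measured and on what is new or still open speak of the compounds shown alone.

Working notes on the chalcone series in an assay on isolated protein for inhibition of Amine oxidase [flavin-containing] B (Homo sapiens); a higher number here means a weaker inhibitor, a lower number a stronger inhibitor.

Compound 2 `CCc1ccc(/C=C/C(=O)c2ccc(-n3ccnc3)cc2)cc1` gives 320 nM; this is the highest of the two numbers shown, with compound 3 `CCOc1ccc(C(=O)/C=C/c2ccc(CC)cc2)cc1` nearest at 210 nM, a step of a 1.5-fold lower number from compound 2 to compound 3 (0.18 log units; within the scatter) that stays within the scatter. Compound 1 `O=C(/C=C/c1cccc(F)c1)c1ccc(-n2ccnc2)cc1` gives only a limit in this assay, > 10000 nM, as described by the limit of > 10000 nM in this assay, at which 1 of the 3 values shown sits.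

Compound 4 `O=C(/C=C/c1ccc(Br)cc1)c1ccc(-n2ccnc2)cc1` differs from compound 2 by bromo in place of ethyl on an aromatic carbon. Among the measured compounds shown here, no measured step changes this position, and the one measured step, from compound 2 to compound 3, concerns the other ring, so it gives no direct guide. The change is therefore expected to leave the number near that of compound 2, with an expected step of a 1.1-fold lower number from compound 2 to compound 4 (0.03 log units; within the scatter) within the scatter. Compound 4 is estimated at 300 nM, in the range 100 nM to 1000 nM.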

Compound 4, half-maximal inhibitory concentration: 320 nM
For compound 4 the middle estimate is 1.1-fold (0.03 log units) below the measured one; measured number inside the range.
By their numbers in this assay, from the lowest: compounds 3, 2 and 4 (each within the scatter of the next). At a limit, above all of these: compound 1.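

With bromo in place of ethyl on this aromatic carbon, para to a large group, the number holds (no change at the digits printed from compound 2 to compound 4 (within the scatter)). The change from 3-fluorophenyl to 4-bromophenyl counts for far more (an at least 31-fold lower number from compound 1 to compound 4 (1.49 log units; beyond the scatter)). Compound 1 stands at a limit, so this step gives only a bound: the limit of > 10000 nM in this assay, at which 1 of the 4 values shown sits.

From the compounds shown here alone, it remains open whether an amine or a carboxylic acid on this carbon would also hold the number. Also open, going by these compounds, is whether 4-fluorophenyl or 3-bromophenyl would separate the halogen from its place on the ring.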